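A few compounds are considered here, and "the series" means these few. Any claim that something is new, unique, unknown or untested is made for them only; others in the source may bear on it.

Measured so far:

compound 1, `NC(=O)c1cn(-c2ccc(O)c(Cl)c2)c2cc(-c3ccncc3)ccc2c1=O`: 2000 nM
compound 2, `NC(=O)c1cn(-c2ccc(O)cc2C(F)(F)F)c2cc(-c3ccncc3)ccc2c1=O`: 20000 nM
compound 3, `NC(=O)c1cn(-c2ccc(O)cc2Cl)c2cc(-c3ccoc3)ccc2c1=O`: 2000 nM

In an assay on isolated protein for inhibition of Calpain-1 catalytic subunit (Homo sapiens) (on this read-out higher numbers stand for weaker inhibition and lower numbers for stronger inhibition), compound 3 gives 2000 nM. Compound 1, with a different pattern on the phenol ring and a different ring at the far end of the core, gives 2000 nM, the same number at the digits recorded; the two stand together as the lowest of the three. Differing from compound 3 in two places, compound 2 gives 20000 nM, a higher number well beyond the scatter; with two changes at once, no single step can be read from that pair.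

Compound 4, `NC(=O)c1cn(-c2ccc(O)cc2Cl)c2cc(-c3ccccn3)ccc2c1=O`, is not yet measured. It differs from compound 3 in one place: pyridin-2-yl in place of furan-3-yl on an aromatic carbon. Within the data shown here, no measured pair shows this exchange, so its effect has to be guessed from the spread seen so far. Both six- and five-membered rings at this position have given numbers in the same region (compound 1 and compound 3), so no step beyond the scatter is expected in either direction, with a slight lean toward a higher number. Compound 4 is therefore estimated at 3000 nM, with a range of 1000 nM to 10000 nM. This estimate corresponds to a 1.5-fold higher number from compound 3 to compound 4 (0.18 log units; within the scatter), within the usual scatter.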

Compound 4, half-maximal inhibitory concentration: 30000 nM
For compound 4 the middle estimate is 10-fold (1.00 log units) below the measured one; the measured number lies above the stated range.
By their numbers in this assay, from the lowest: compounds 1 and 3 (each within the scatter of the next); then compounds 2 and 4 (each within the scatter of the next).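

In this assay, among these compounds, the exchange of furan-3-yl for pyridin-2-yl on this aromatic carbon gives a 15-fold higher number from compound 3 to compound 4 (1.18 log units; beyond the scatter) and is the first effect that can be read from a single change. Among the compounds shown here, it shows that this position does not accept every aromatic ring equally, a point the earlier compounds could not settle: they differ from one another in more than one place, so no steps can be read among them. Nothing at hand accounts for the size of this step.

Going by these compounds, a single exchange cannot separate the move from a five-membered to a six-membered ring from the introduction of pyridin-2-yl as such, so it remains open which of these goes with the higher number. On the phenol ring of compound 3, a plain phenyl, a pyridin-3-yl or a thiophen-3-yl group at this position would help to separate ring size from the identity and placement of the hetero atom, and the same holds for a pyridin-2-yl bearing an amine.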